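Butyl-substituted core, aryl substituent changes, receptor binding

The source may hold more compounds than are shown below. What is called first, only, known or untested is meant among the compounds shown, and "the series" means these compounds.

Measured compounds:
compound 1 `C=C1C(C)=C(C#N)C(=O)N1c1c(C(C)C)cccc1C(C)C` — 23500 nM
compound 2 `C=C1C(CCCC)=C(C#N)C(=O)N1c1cccc(Cl)c1C` — 8300 nM
compound 3 `C=C1C(CCCC)=C(C#N)C(=O)N1c1cc(Cl)ccc1C` — 12500 nM

In an assay on isolated protein for binding affinity to ecdysone receptor (Lucilia cuprina), read by fluorescence polarization, with a stated time of 3 h (on this read-out higher numbers stand for weaker inhibition and lower numbers for stronger inhibition), compound 1 gives 23500 nM, compound 2 gives 8300 nM and compound 3 gives 12500 nM. On these three numbers compound 3 lies between compound 2 and compound 1, and its distance to each of them is within the usual scatter, so nothing separates the three beyond repeat variation. Within the data shown here, no single-point step between measured compounds is available in this set.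

Compound 4 `C=C1C(CCCC)=C(C#N)C(=O)N1c1cc(Cl)ccc1C(C)(C)C` is the next compound and is to be measured in this assay. Relative to compound 3 the change is tert-butyl in place of methyl on an aromatic carbon. Among the measured compounds shown here, with no comparable step measured, the expectation is that compound 4 stays close to compound 3, with a step from compound 3 to compound 4 of a 1.2-fold higher number from compound 3 to compound 4 (0.08 log units; within the scatter) expected, which is not beyond the scatter. Compound 4 is therefore estimated at 15000 nM, with a range from 5000 nM to 45000 nM.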

Compound 4, half-maximal inhibitory concentration: 5500 nM
The estimate for compound 4 lay 2.7-fold (0.44 log units) above the measured number, and the stated range covers the measured number.
By their numbers in this assay, from the lowest: compounds 4, 2, 3 and 1 (each within the scatter of the next, the first and the last beyond it).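

In this assay, the aromatic carbon para to the chloro group tolerates a group far larger than methyl: tert-butyl in place of methyl gives a 2.3-fold lower number from compound 3 to compound 4 (0.36 log units; beyond the scatter) and binding improves rather than being lost. Among these compounds, this is the first single-place comparison and the only step so far that lies beyond the scatter, so this position can influence binding even though the earlier values could not be separated. No supporting measurement bears on why this change strengthens inhibition.

From the compounds shown here alone, it remains open whether the response follows the size of the group, as ethyl or isopropyl at the same carbon would test, or is particular to tert-butyl. Also open, going by these compounds, is whether a group carrying heteroatoms, such as an amine or a methoxy group, would be accepted there, and whether the gain persists with the butyl chain replaced by a shorter chain.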